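The compounds below may be only part of what the source reports. "The series", "measured", "known", "first", "only" and "open" are said of these compounds alone.

In a functional assay on HCT-116 cells (Homo sapiens) for inhibition, read by MTT assay, with a stated time of 72 h (on this read-out higher numbers stand for weaker inhibition of growth and lower numbers for stronger inhibition of growth), compound 1 (`COc1ccc(-c2nc3c(N4CCN(Cc5cc(C)on5)CC4)c(Br)cnc3[nH]2)cc1`) gives 540 nM and compound 2 (`CN(C)c1ccc(-c2nc3c(N4CCN(CC(=O)Nc5cccnc5)CC4)c(Br)cnc3[nH]2)cc1`) gives 1650 nM, so compound 2 holds the higher of the two numbers, a gap beyond the usual scatter. Compound 3 (`CN(C)c1ccc(-c2nc3c(N4CCN(Cc5ccncc5)CC4)c(Br)cnc3[nH]2)cc1`) carries pyridin-4-yl in place of (pyridin-3-yl)carbamoyl on a saturated chain carbon bound to an amine nitrogen in a ring. Within the data shown here, no measured step covers this change. A moderate move toward stronger inhibition in this assay is expected, since compound 1 without a carbamoyl gives 540 nM. The estimated change is a 2.2-fold lower number from compound 2 to compound 3 (0.34 log units; beyond the scatter). For compound 3 the estimate is 750 nM, with an expected range from 300 nM to 1800 nM.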

Compound 3, concentration for 50% growth inhibition: 700 nM
For compound 3 the middle estimate is 1.1-fold (0.03 log units) above the measured one; the measured number falls inside the stated range.
By their numbers in this assay, from the lowest: compounds 1 and 3 (each within the scatter of the next); then compound 2.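

In this assay, replacing ((pyridin-3-yl)carbamoyl)methyl with (pyridin-4-yl)methyl gives a 2.4-fold lower number from compound 2 to compound 3 (0.37 log units; beyond the scatter) on a saturated chain carbon bound to an amine nitrogen in a ring. This shows that growth inhibition responds to a change at this place, and that the carbamoyl with its amide hydrogen is not required for activity. No evidence is available to explain the step.

The step changes both the carbamoyl and the attachment of the pyridine at once, so their shares remain unseparated. A (pyridin-3-yl)methyl or benzyl group at this place would separate them.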